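This account rests on a few compounds, and the source may have more. Where it says the series, first, only, none or still open, it means among the compounds named here.

Measured compounds in an ADME assay on L929 cells (Mus musculus) for cytotoxicity, read by resazurin assay, with a stated time of 72 h; a higher number here means a weaker inhibitor, a lower number a stronger inhibitor:
- compound 1 `O=C(/C=C/c1ccc2c(c1)B(O)OC2)c1ccccc1` gives only the assay limit > 10 ug/mL.
- compound 2 `COc1cccc(C(=O)/C=C/c2ccc3c(c2)B(O)OC3)c1` gives only the assay limit > 10 ug/mL.
- compound 3 `COCOc1cccc(C(=O)/C=C/c2ccc3c(c2)B(O)OC3)c1` gives only the assay limit > 10 ug/mL.

Compound 2 stands at the limit of this assay, and nothing else is known of it there; the same holds for every value in the set (the limit of > 10 ug/mL in this assay, at which 3 of the 3 values shown sit). The steps between the measured compounds, a step that the two limits leave unreadable from compound 1 to compound 2, a step that the two limits leave unreadable from compound 1 to compound 3 and a step that the two limits leave unreadable from compound 2 to compound 3, are therefore all unreadable in size: each join two limits.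

The next compound is compound 4 `COc1cc(C(=O)/C=C/c2ccc3c(c2)B(O)OC3)ccc1N`. It differs from compound 2 by amino in place of hydrogen on an aromatic carbon.

Among the measured compounds shown here, no measured step bears readably on this change. For the measured compounds named here, what the series shows is only that substitution on that ring in compound 2 and compound 3 did not bring either compound below the limit. The expectation for this assay is accordingly a step that the limit leaves unreadable from compound 2 to compound 4, nothing beyond the scatter in either direction, with a readable value unlikely. Compound 4 is estimated at 20 ug/mL, with a range of 7 ug/mL to 60 ug/mL.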

Compound 4, half-maximal inhibitory concentration: 1.45 ug/mL
Compound 4: middle estimate off by 14-fold (1.14 log units), on the high side; the measured number lies below the stated range.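

In this assay, among the compounds shown here, amino on this aromatic carbon, ortho to a methoxy group and para to a large group, gives an at least 6.8-fold lower number from compound 2 to compound 4 (0.83 log units; beyond the scatter) and so the first readable step. Compound 2 gives > 10 ug/mL as a limit of the assay, so the full size of the step stays unread. For the compounds shown here, the steps among compound 1, compound 2 and compound 3 cannot be read, which makes amino the only change here that yields a readable value: the limit of > 10 ug/mL in this assay, at which 3 of the 4 values shown sit.

The compounds shown do not tell whether the step depends on the methoxy group ortho to the amino. Going by these compounds, how a hydroxyl, an acetamide or a dimethylamino group on the same carbon would read in this assay also remains open.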